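The compounds below may be only part of what the source reports. "The series", "measured", "known", "first", "only" and "open" are said of these compounds alone.

Compound 3 `COc1ccccc1N1C(=O)CSC1c1cccc(C(=O)N2CCCCC2)c1` carries a (piperidin-1-yl)carbonyl group on the shared core. In a functional assay on A549 cells (Homo sapiens) for antiproliferative activity, read by sulforhodamine B assay, with a stated time of 48 h (on this read-out lower numbers stand for stronger inhibition and higher numbers for weaker inhibition), compound 3 gives > 50000 nM, which is a limit of the assay and not a number. Its two measured relatives are compound 1 `CCN(CC)C(=O)c1cccc(C2SCC(=O)N2c2ccccc2OC)c1` and compound 2 `C=CCN(CC=C)C(=O)c1cccc(C2SCC(=O)N2c2ccccc2OC)c1`. In this assay compound 1 gives > 50000 nM, again a limit. In this assay compound 2 gives > 50000 nM, also a limit. The three steps among them, a step that the two limits leave unreadable from compound 1 to compound 2, a step that the two limits leave unreadable from compound 1 to compound 3 and a step that the two limits leave unreadable from compound 2 to compound 3, cannot be read because of the limit of > 50000 nM in this assay, at which 3 of the 3 values shown sit. Compound 4 `COc1ccccc1N1C(=O)CSC1c1cccc(C(=O)Nc2ccccc2)c1` differs from compound 3 in one place: anilino in place of piperidin-1-yl on a carbonyl carbon. The change replaces one group on the carbonyl carbon with another, and the measured steps offer no readable size for any such exchange. The expected step is a number no higher from compound 3 to compound 4 (the limit leaves the size open), that is, none beyond the scatter. Compound 4 is therefore expected to give 50000 nM in this assay, within 15000 nM to 150000 nM, most probably again only as a limit.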

Compound 4, half-maximal inhibitory concentration: > 25000 nM
Compound 4 gave a limit, no number (the forecaster's own chance of this, stated with the estimate: 75%); the middle value does not contradict the limit.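

Compound 4, like compound 1, compound 2 and compound 3, gives only a limit in this assay, so no new step among these compounds can be read. The compounds shown leave open whether any group on that carbonyl carbon gives a measurable value in this assay.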